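Removing an ester arm from the purine core

The compounds below may be only part of what the source reports. "The series", "measured", "known", "first", "only" and "open" are said of these compounds alone.

The opening compound, compound 1 `Nc1nc(Oc2ccc(Cl)cc2)c2nc[nH]c2n1`, carries a chloro-substituted phenoxy group on the shared core, and in an ADME assay on Vero cells (Chlorocebus sabaeus) for cytotoxicity (on this read-out lower numbers stand for higher toxicity in this test and higher numbers for lower toxicity in this test), compound 1 shows "not determined" (no result reported). Compound 3 `CCCCCCCCCCOc1nc(N)nc2c1ncn2CC(=O)OCC` likewise has no result, as compound 3 shows "not determined" (no result reported). Compound 2 `CCCCCCCCCCCCOc1nc(N)nc2c1ncn2CC(=O)OCC` is the only one with an entry, and that entry is a limit rather than a number: compound 2 gives > 10 ug/mL. Among the three values shown, compound 2 therefore stands at the limit of this assay, as described by the limit of > 10 ug/mL in this assay, at which 1 of the 3 values shown sits, with the other two entries holding no number at all.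

The step from compound 2 leads to compound 4 `CCCCCCCCCCCCOc1nc(N)nc2[nH]cnc12`. The change, (hydrogen in place of (ethoxycarbonyl)methyl on an aromatic nitrogen), places a hydrogen where the (ethoxycarbonyl)methyl stood on the aromatic nitrogen of the five-membered ring. Among the compounds with values here, no step between measured compounds is available to gauge its size, so the expected shift a step that the limit leaves unreadable from compound 2 to compound 4 is none beyond the usual scatter. Compound 4 is accordingly estimated at 15 ug/mL, within a range from 5 ug/mL to 50 ug/mL.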

Compound 4, half-maximal cytotoxic concentration: > 10 ug/mL
Compound 4 gave a limit, no number (the forecaster's own chance of this, stated with the estimate: 60%); the middle value lies beyond the limit too.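

No size can be read for the step from compound 2 to compound 4, since both compounds end at a limit of the assay rather than a number: the limit of > 10 ug/mL in this assay, at which 2 of the 4 values shown sit.

The compounds shown leave open whether hydrogen in place of (ethoxycarbonyl)methyl changes the read-out in this assay at all, and in which direction.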